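The compounds below may be only part of what the source reports. "The series", "measured", "known", "first", "only" and "open" are said of these compounds alone.

Measured so far:
compound 1, `CCCCN(CC)c1nc(C)nc2c1nnn2-c1c(C)cc(C)nc1C`: 65 nM
compound 2, `COCC(COC)Nc1nc(C)nc2c1nnn2-c1ccc(C(C)C)cc1Br`: 10.3 nM
compound 3, `COCC(COC)N(C)c1nc(C)nc2c1nnn2-c1ccc(C(C)C)cc1Br`: 21.3 nM

All three were tested in an in vitro assay on 293-EBNA cells for binding affinity to corticotropin-releasing factor receptor 1 (Homo sapiens); on this read-out higher numbers stand for weaker inhibition and lower numbers for stronger inhibition. Compound 3 sits second highest of the three numbers. Its nearest neighbour is compound 2, which differs only by a methyl in place of hydrogen on a nitrogen on an aromatic ring, giving a 2.1-fold higher number from compound 2 to compound 3 (0.32 log units; beyond the scatter). Compound 1, with a different core and side chains, gives 65 nM, a higher number than compound 3 shows.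

Compound 4, `CCC(Nc1nc(C)nc2c1nnn2-c1ccc(C(C)C)cc1Br)C(=O)OC`, is not yet measured. Compared with compound 3 the change is a group of 8 heavy atoms (5 carbon, 1 nitrogen, 2 oxygen; no ring) in place of a group of 9 heavy atoms (6 carbon, 1 nitrogen, 2 oxygen; no ring), on an aromatic carbon: the group that enters carries one hydrogen-bond donor and one double bond outside aromatic rings, while the group that leaves carries no donor. Among the compounds with values here, the only step that bears on this is the one between compound 2 and compound 3, where removing the hydrogen on the nitrogen gave a 2.1-fold higher number from compound 2 to compound 3 (0.32 log units; beyond the scatter). Since compound 4 brings a hydrogen back onto that nitrogen, a modest lower number is expected, roughly reversing that step, though the rest of the entering group is new and untested here. The expected step is a 1.5-fold lower number from compound 3 to compound 4 (0.18 log units; within the scatter). Compound 4 is therefore estimated at 14 nM, within a range of 5 nM to 40 nM.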

Compound 4, inhibition constant: 19.4 nM
Beside the measured number, compound 4's estimate is 1.4-fold (0.14 log units) below it, within the range that was stated.
By their numbers in this assay, from the lowest: compounds 2, 4 and 3 (each within the scatter of the next, the first and the last beyond it); then compound 1.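

In this assay, the exchange of the whole side chain on the aromatic carbon gives a 1.1-fold lower number from compound 3 to compound 4 (0.04 log units; within the scatter), so a hydrogen on that nitrogen does not by itself set compound 4 apart from compound 3. With the hydrogen kept, 1-(methoxycarbonyl)propyl in place of 2-methoxy-1-(methoxymethyl)ethyl gives a 1.9-fold higher number from compound 2 to compound 4 (0.27 log units; within the scatter), which shows that this position can carry a chain with a carbonyl and still fall within the scatter of both neighbours, even though those two neighbours differ from each other by more than the scatter. Nothing shown here explains these results.

On these data alone, it remains open whether a methyl on the nitrogen of compound 4 would shift the number as it did for the earlier pair. As far as these compounds go, how a carboxylic acid or a primary amide in place of the methyl ester would read in this assay is also open.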